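A few compounds are considered here, and "the series" means these few. Any claim that something is new, unique, unknown or untested is made for them only; others in the source may bear on it.

Working notes on the series.

Compound 1 `O=c1[nH]c2ccccc2n1CCCN1CCN(S(=O)(=O)c2ccc([N+](=O)[O-])cc2)CC1` and compound 2 `O=c1[nH]c2ccccc2n1CCCN1CCN(S(=O)(=O)c2ccc(F)cc2)CC1` carry a sulfonylated piperazine; compound 3 `O=c1[nH]c2ccccc2n1CCCCCN1CCN(C(c2ccccc2)c2ccccc2)CC1` carries a benzhydryl piperazine instead. In an assay on RPMI-8226 cells for antagonist activity at P2X purinoceptor 7 (Homo sapiens), read by calcium flux (a higher number here means a weaker inhibitor, a lower number a stronger inhibitor), compound 1 reaches only the limit of > 10000 nM. In this assay compound 2 likewise reaches only the limit of > 10000 nM. The step from compound 1 to compound 2, a step that the two limits leave unreadable from compound 1 to compound 2, therefore cannot be read, and the only recorded cause of that is the limit of > 10000 nM in this assay, at which 2 of the 3 values shown sit. For the measured compounds named here, compound 3 in this assay gives 560 nM, the single numerical value in the set.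

Compound 4 `COc1ccc2c(ccn2CCCCN2CCN(C(c3ccccc3)c3ccccc3)CC2)c1` differs from compound 3 by a group of 11 heavy atoms (9 carbon, 1 nitrogen, 1 oxygen; one five-membered aromatic ring with 1 hetero atom, one six-membered aromatic ring of carbon only) in place of a group of 11 heavy atoms (8 carbon, 2 nitrogen, 1 oxygen; one five-membered aromatic ring with 2 hetero atoms, one six-membered aromatic ring of carbon only), on a saturated chain carbon, four bonds along the chain from an amine nitrogen in a ring. Going by the values given here, no measured step touches this end of the molecule: the one readable comparison, between compound 1 and compound 2, concerns the sulfonyl aryl group and is itself unreadable. The benzhydryl piperazine that distinguishes compound 3 from compound 1 and compound 2 is kept in compound 4, so the step from compound 3 to compound 4 in this assay is expected to stay within the usual scatter, with its direction open, estimated as a 1.4-fold higher number from compound 3 to compound 4 (0.15 log units; within the scatter). Compound 4 is accordingly expected to give about 800 nM in this assay, within a range from 200 nM to 4000 nM.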

Compound 4, half-maximal inhibitory concentration: > 10000 nM
Compound 4: only a limit was reported; the forecaster's own chance of this, stated with the estimate: 15%; middle value at least 12-fold (1.09 log units) away from the limit.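

In this assay compound 4 gives > 10000 nM, which is a limit of the assay and not a number. For the compounds shown here, with the benzhydryl piperazine kept, putting 5-methoxy-1H-indol-1-yl in place of the group that leaves, on a saturated chain carbon, four bonds along the chain from an amine nitrogen in a ring, comes with an at least 17-fold higher number from compound 3 to compound 4 (1.25 log units; beyond the scatter); this is the first readable step and the first to touch this end of the molecule, so the benzhydryl piperazine alone does not carry the inhibition seen with compound 3, and this end of the molecule matters as well. The true size of the step cannot be read, and the series still rests on a single number: the limit of > 10000 nM in this assay, at which 3 of the 4 values shown sit.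

The compounds shown leave open which part of the exchange matters, the loss of the group with 1 hydrogen-bond donor or the arrival of the methoxy, and a plain 1H-indol-1-yl group at the same place would bear on this. Also open, going by these compounds, is how a longer chain, or an amine or a carboxylic acid on the aromatic ring of the entering group, would read in this assay.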